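A Single Methoxy Group Added to Compound 3

This account rests on a few compounds, and the source may have more. Where it says the series, first, only, none or still open, it means among the compounds named here.

Compound 1, `COc1cc(/C=N/NC(=O)Nc2cccc3ccccc23)cc(OC)c1OC`: 100 mg/kg
Compound 2, `COc1cc(/C=N/NC(=O)Nc2cccc3ccccc23)ccc1O`: 300 mg/kg
Compound 3, `O=C(N/N=C/c1ccccc1)Nc1cccc2ccccc12`: 300 mg/kg

All three were tested in a functional assay on the whole organism (strain Swiss albino) with Mus musculus as the target, in the maximal electroshock model, with a stated time of 0.5 h; on this read-out higher numbers stand for an effect only at larger amounts of compound and lower numbers for an effect already at smaller amounts. Compound 3 stands level with compound 2 at the digits recorded; together they give the highest numbers of the three, while compound 1 gives a lower number, a gap beyond the scatter. Compound 4, `COc1ccc(/C=N/NC(=O)Nc2cccc3ccccc23)cc1`, awaits measurement. It differs from compound 3 in one place: methoxy in place of hydrogen on an aromatic carbon. Within the data shown here, no measured pair isolates this single change, so the expectation rests on the whole set. Compound 1, with three methoxy groups, gives 100 mg/kg in this assay, whereas compound 2, with one methoxy group and one hydroxyl, gives 300 mg/kg. A single added methoxy group is therefore expected to bring at most a small shift. The expected step is a 1.5-fold lower number from compound 3 to compound 4 (0.18 log units; within the scatter), within the scatter. Compound 4 is estimated to give 200 mg/kg, between 100 mg/kg and 300 mg/kg.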

Compound 4, minimum effective dose: 300 mg/kg
For compound 4 the middle estimate is 1.5-fold (0.18 log units) below the measured one; low and high end bracket the measured number.
By their numbers in this assay, from the lowest: compound 1; then compounds 2, 3 and 4 (each within the scatter of the next).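

In this assay, replacing phenyl with 4-methoxyphenyl brings no change at the digits printed from compound 3 to compound 4 (within the scatter). Among these compounds, this is the first pair in the set that differs in only one place, and it shows that a single methoxy group on this aromatic carbon, para to a large group, leaves the minimum effective dose where it was. Nothing measured here explains this flat result.

From the compounds shown here alone, it remains open whether an amine, a carboxylic acid or a longer chain such as ethoxy at this same place would shift the dose.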